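Iodo for fluoro on two unrelated cores

The source may report more compounds than this note shows. Statements on the series, on what has been measured and on what is new or still open speak of the compounds shown alone.

Measured so far:
Compound 1, `O=C1O/C(=C\Cn2cc(F)c(=O)[nH]c2=O)C(OCc2ccccc2)=C1OCc1ccccc1`, gives 5100 nM in an ADME assay on L1210/0 cells (Mus musculus) for cytotoxicity, with a stated time of 48 h; a higher number here means a weaker inhibitor, a lower number a stronger inhibitor.
Compound 2, `O=C1O/C(=C\Cn2cc(I)c(=O)[nH]c2=O)C(OCc2ccccc2)=C1OCc1ccccc1`, gives 7500 nM in this assay.
Compound 3, `CC(=O)OC(C)Cn1cnc2c(Cl)nc(F)nc21`, gives 37000 nM in this assay.

The exchange of fluoro for iodo appears in two pairs of compounds. From compound 1 to compound 2 the change is iodo in place of fluoro on an aromatic carbon, and it made a step of a 1.5-fold higher number from compound 1 to compound 2 (0.17 log units; within the scatter). Compound 4, `CC(=O)OC(C)Cn1cnc2c(Cl)nc(I)nc21`, carries the same kind of change on a different core: iodo in place of fluoro on an aromatic carbon. The difference between the two cores is not broken down here. The surroundings also differ: in compound 4 the carbon lies between two ring nitrogen atoms, meta to a chloro group, meta to a fused ring and para to a fused ring, whereas in compound 2 it is ortho to a group of 1 heavy atom and meta to a large group. Compound 3 stands highest of the three values. Because the earlier step was a 1.5-fold higher number from compound 1 to compound 2 (0.17 log units; within the scatter), the step to compound 4 is expected to be about a 1.2-fold higher number from compound 3 to compound 4 (0.09 log units; within the scatter), with a wider range given the different core. Compound 4 is therefore estimated at 45000 nM, between 15000 nM and 150000 nM.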

Compound 4, half-maximal inhibitory concentration: 13000 nM
Beside the measured number, compound 4's estimate is 3.5-fold (0.54 log units) above it, and the stated range ends above it.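

In this assay, iodo in place of fluoro gave a 2.8-fold lower number from compound 3 to compound 4 (0.45 log units; beyond the scatter) on the core of compound 3, and the same change did not carry over evenly between the two cores: the same change on two cores in this assay, a 1.5-fold higher number (0.17 log units; within the scatter) from compound 1 to compound 2 and a 2.8-fold lower number (0.45 log units; beyond the scatter) from compound 3 to compound 4, 4.2-fold (0.62 log units) apart, beyond the scatter of two such steps

For these two pairs, then, the step on the core of compound 1 was a poor guide to the step on the core of compound 3. Two pairs cannot show why the steps differ, whether the cores themselves or the surroundings of the changed carbon matter, or how a further core would respond.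

The compounds shown leave open how a bromo group or an amine on the same carbon would compare with fluoro and iodo on either core.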